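The source may hold more compounds than are shown below. What is called first, only, known or untested is meant among the compounds shown, and "the series" means these compounds.

Of the compounds shown here, three have been tested in a functional assay on CHO cells for antagonist activity at prostaglandin E2 receptor EP4 subtype (Homo sapiens), read by calcium flux, with a stated time of 15 min; on this read-out higher numbers stand for weaker inhibition and lower numbers for stronger inhibition. Compound 1 `Cc1c(C(=O)N[C@@H](C)c2ccc(C(=O)O)cc2)nnn1Cc1ccc(C(F)(F)F)cc1` gives only a limit, > 10000 nM, and no number. Compound 2 `COc1cccc(Cn2nnc(-c3ccccc3)c2C(=O)N[C@@H](C)c2ccc(C(=O)O)cc2)c1` gives 96.8 nM. Compound 3 `C[C@H](NC(=O)c1c(C2CCC2)nnn1Cc1ccc(C(F)(F)F)cc1)c1ccc(C(=O)O)cc1` gives 75.3 nM, the lower of the two numbers, though its gap to compound 2 lies within the scatter of repeated measurements. Compound 4 `C=CCc1nnn(Cc2ccc(C(F)(F)F)cc2)c1C(=O)N[C@@H](C)c1ccc(C(=O)O)cc1` has not been measured; it differs from compound 3 by allyl in place of cyclobutyl on an aromatic carbon. For the measured compounds named here, no step between two measured compounds isolates this change, so the expected size rests on the spread of the three values alone. Compound 4 is expected to give about 300 nM, between 80 nM and 1500 nM. The expected step of a 4.0-fold higher number from compound 3 to compound 4 (0.60 log units; beyond the scatter) is therefore toward weaker inhibition, by more than the scatter.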

Compound 4, half-maximal inhibitory concentration: > 1000 nM
Compound 4: no number, only a limit; the forecaster's own chance of this, stated with the estimate: 5%; at least 3.3-fold (0.52 log units) between middle value and limit.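

Swapping cyclobutyl for allyl on this aromatic carbon gives an at least 13-fold higher number from compound 3 to compound 4 (1.12 log units; beyond the scatter), the first single-change comparison at this position, and it points to weaker inhibition. So the group here matters greatly, even though the change removes a ring and only one heavy atom and adds a double bond. The result for compound 4 is a limit of the assay, not a number: the limit of > 1000 nM in this assay, at which 1 of the 4 values shown sits.

Still open, from the compounds shown here alone, is which part of the change matters: the lost ring, the double bond or the smaller size. A propyl chain or a cyclopropyl group on this carbon would help separate these.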